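A Carboxy Group Replaced by an Ethyl Ester

This account rests on a few compounds, and the source may have more. Where it says the series, first, only, none or still open, it means among the compounds named here.

In a functional assay on HepG2 cells (Homo sapiens) for inhibition, read by MTT assay, with a stated time of 3 days (on this read-out higher numbers stand for weaker inhibition and lower numbers for stronger inhibition), compound 1 `COc1cc(-c2nc3ccccc3s2)ccc1OCC(=O)NNC(=O)CN(C(C)=O)[C@@H](CS)C(=O)O` gives 3420 nM, compound 2 `COc1cc(-c2nc3ccccc3s2)ccc1OCC(=O)NNC(=O)CN[C@@H](CS(=O)(=O)O)C(=O)O` gives 3690 nM and compound 3 `COc1cc(-c2nc3ccccc3s2)ccc1OCC(=O)NNC(=O)CN[C@@H](CCSC)C(=O)O` gives 3780 nM. Compound 3 therefore stands level with the other two, within the scatter of both.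

Compound 4 `CCOC(=O)[C@@H](NCC(=O)NNC(=O)COc1ccc(-c2nc3ccccc3s2)cc1OC)[C@@H](C)CC` differs from compound 3 on an amine nitrogen, where 1-(ethoxycarbonyl)-2-methylbutyl sits in place of 1-carboxy-3-(methylsulfanyl)propyl: 1-(ethoxycarbonyl)-2-methylbutyl in place of 1-carboxy-3-(methylsulfanyl)propyl on an amine nitrogen.

Three measured steps change this part of the molecule: a 1.1-fold higher number from compound 1 to compound 2 (0.03 log units; within the scatter), a 1.1-fold higher number from compound 1 to compound 3 (0.04 log units; within the scatter) and a 1.0-fold higher number from compound 2 to compound 3 (0.01 log units; within the scatter). All three are small, even though the groups exchanged are quite different. However, compounds 1, 2 and 3 all carry a carboxy group, so the data do not show what replacing it with ethoxycarbonyl does. That gap is the main uncertainty here.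

The expected change in this assay is a 1.1-fold lower number from compound 3 to compound 4 (0.02 log units; within the scatter), so no step beyond the scatter is expected. The estimated value for compound 4 is 3600 nM, with an expected range of 1500 nM to 8000 nM.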

Compound 4, half-maximal inhibitory concentration: 3460 nM
Beside the measured number, compound 4's estimate is 1.0-fold (0.02 log units) above it, within the range that was stated.
By their numbers in this assay, from the lowest: compounds 1, 4, 2 and 3 (each within the scatter of the next).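

Among these compounds, compound 4 is the first compound here with ethoxycarbonyl rather than a free carboxy group in this part of the molecule, and in this assay the exchange on the amine nitrogen gives a 1.1-fold lower number from compound 3 to compound 4 (0.04 log units; within the scatter) as its measured step. The comparisons with the other two give a 1.1-fold lower number from compound 2 to compound 4 (0.03 log units; within the scatter) and a 1.0-fold higher number from compound 1 to compound 4 (0.01 log units; within the scatter) as their steps, so all of them lie within the scatter and the carboxy group is shown not to be required for this level of inhibition. No measurement given here accounts for this flat result.

On these data alone, because compound 4 also differs from compound 3 in its side chain, the effect of the ester alone remains open, and 1-carboxy-2-methylbutyl on the same amine nitrogen would separate the two changes. Also open, as far as these compounds go, is whether a group of another kind here, such as a phenyl ring or a primary amine at the end of a longer chain, would move the number beyond the scatter.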